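The compounds below may be only part of what the source reports. "The series", "measured", "known", "first", "only" and "open" are said of these compounds alone.

Measured compounds:
compound 1 `O=C1N/C(=N/c2csc(-c3ccc(Cl)cc3)c2)S/C1=C\c1ccc(Br)cc1` – 2500 nM
compound 2 `O=C1N/C(=N/c2csc(-c3ccc(Cl)cc3)c2)S/C1=C\c1ccc2ccccc2c1` – 1200 nM

Both numbers come from a functional assay on MCF7 cells (Homo sapiens) for cytotoxicity, read by MTT assay, with a stated time of 72 h; a lower number here means a stronger inhibitor, a higher number a weaker inhibitor. Among the measured compounds shown here, of the two measured compounds, compound 2 gives the lower number, and the one step between them, a 2.1-fold lower number from compound 1 to compound 2 (0.32 log units; beyond the scatter), lies beyond the scatter. Compound 2 therefore stands lowest of the two, with compound 1 nearest.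

Compound 3 `CCCCCC/C=C1\S/C(=N\c2csc(-c3ccc(Cl)cc3)c2)NC1=O` has not yet been measured. It differs from compound 2 at a single place: hexyl in place of naphthalen-2-yl on a double-bonded chain carbon bound to a double-bonded ring carbon. For the measured compounds named here, only one measured step touches this place, a 2.1-fold lower number from compound 1 to compound 2 (0.32 log units; beyond the scatter), and it compared two groups that both carry aromatic rings; nothing measured so far carries a chain without any ring here, so the step to compound 3 is weakly anchored. With that single step favouring the group with two rings, a modest rise in the number is expected for compound 3 in this assay, roughly a 3.3-fold higher number from compound 2 to compound 3 (0.52 log units; beyond the scatter), and a wide range is kept to reflect the thin evidence.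

Compound 3 is thus estimated at 4000 nM, with a range from 1200 nM to 14000 nM.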

Compound 3, half-maximal inhibitory concentration: > 50000 nM
Compound 3 gave a limit, no number; the forecaster's own chance of this, stated with the estimate: 10%; middle value at least 12-fold (1.09 log units) away from the limit.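

In this assay compound 3 gives > 50000 nM, which is a limit and not a number, and it is the only value of this kind here: the limit of > 50000 nM in this assay, at which 1 of the 3 values shown sits.

Among the compounds shown here, the earlier comparison showed only that exchanging one aromatic group for another at this place, on a double-bonded chain carbon bound to a double-bonded ring carbon, shifts the result modestly: a 2.1-fold lower number from compound 1 to compound 2 (0.32 log units; beyond the scatter). Leaving the aromatic rings out altogether and using hexyl gives far larger steps, an at least 41-fold higher number from compound 2 to compound 3 (1.61 log units; beyond the scatter) and an at least 20-fold higher number from compound 1 to compound 3 (1.30 log units; beyond the scatter), and the true size of both remains unknown. Among these three compounds, the two with aromatic rings at this place give measured numbers, whereas the one with an open chain gives none, so having an aromatic ring here matters more than the difference between 4-bromophenyl and naphthalen-2-yl.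

The compounds shown leave open whether any group without an aromatic ring can give a measurable number here, such as a shorter ethyl chain, a cyclohexyl ring or a chain ending in an amine. They also leave open how a plain phenyl ring, or a phenyl ring carrying a carboxylic acid, would compare with the two aromatic groups tested.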